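Swapping Piperidine for Imidazole in Mouse Microsomes

The source may hold more compounds than are shown below. What is called first, only, known or untested is meant among the compounds shown, and "the series" means these compounds.

Compound 1, `COC(=O)C1=C(CN2CCCCC2)NC(c2nccs2)=NC1(C)c1ccc(F)cc1`: 88 mL/min/kg
Compound 2, `COC(=O)C1=C(CN2CCNC(=O)C2)NC(c2nccs2)=NC1(C)c1ccc(F)cc1`: 81 mL/min/kg

Both were measured in an ADME assay on microsomes from liver (Mus musculus) for metabolic stability, read by LC-MS, using NADPH, with stated times of 10 min and 30 min, tested at 1 uM; a higher number here means faster removal of the compound, a lower number slower removal. Compound 1 stands highest of the two numbers, but its nearest neighbour is close: the step of a 1.1-fold lower number from compound 1 to compound 2 (0.04 log units; within the scatter) lies within the scatter, so the two results cannot be told apart. Compound 3, `COC(=O)C1=C(Cn2ccnc2)NC(c2nccs2)=NC1(C)c1ccc(F)cc1`, has not yet been measured; it differs from compound 1 by 1H-imidazol-1-yl in place of piperidin-1-yl on a saturated chain carbon bound to a double-bonded ring carbon. For the measured compounds named here, only one measured step bears on this, the change at the same carbon, a 1.1-fold lower number from compound 1 to compound 2 (0.04 log units; within the scatter), which stayed within the scatter. Going by the values given here, no measured step exchanges a non-aromatic ring for an aromatic one, so the expectation rests on that single step alone. Compound 3 is expected to give 80 mL/min/kg in this assay, with a range from 45 mL/min/kg to 140 mL/min/kg. The expected step is a 1.1-fold lower number from compound 1 to compound 3 (0.04 log units; within the scatter), which would stay within the scatter.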

Compound 3, clearance: 69 mL/min/kg
Compound 3: the middle estimate sits 1.2-fold (0.06 log units) above what was measured, within the range that was stated.
By their numbers in this assay, from the lowest: compounds 3, 2 and 1 (each within the scatter of the next).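

In this assay, an aromatic ring now stands on this saturated chain carbon: 1H-imidazol-1-yl in place of piperidin-1-yl gives one step (a 1.3-fold lower number from compound 1 to compound 3 (0.11 log units; within the scatter)), and 1H-imidazol-1-yl in place of 3-oxopiperazin-1-yl gives another (a 1.2-fold lower number from compound 2 to compound 3 (0.07 log units; within the scatter)). Neither step can be told apart from repeat measurement, so neither the five-membered aromatic ring nor the two six-membered non-aromatic rings set themselves apart on clearance in these three compounds. No measured information explains why these numbers stay together.

The compounds shown leave open whether the number would move with a group that is not a ring, such as an open-chain dimethylamino group or a carboxylic acid. They also leave open what a longer chain between the ring and the shared core would do.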